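Removing a Fluorine from the Benzyl Ring of Compound 3

The source may report more compounds than this note shows. Statements on the series, on what has been measured and on what is new or still open speak of the compounds shown alone.

In an assay on microsomes from liver for inhibition of 3-hydroxy-3-methylglutaryl-coenzyme A reductase (Rattus norvegicus), read by scintillation counting, with stated times of 0.5 h and 0.75 h (a higher number here means a weaker inhibitor, a lower number a stronger inhibitor), the measured compounds gave:
Compound 1 `Cc1c(C(=O)NCc2ccccc2)nc(-c2ccc(F)cc2)n1CC[C@@H](O)C[C@@H](O)CC(=O)O`: 94 nM
Compound 2 `CCc1c(C(=O)NCc2ccccc2)nc(-c2ccc(F)cc2)n1CC[C@@H](O)C[C@@H](O)CC(=O)O`: 123 nM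
Compound 3 `O=C(O)C[C@H](O)C[C@H](O)CCn1c(-c2ccc(F)cc2)nc(C(=O)NCc2ccc(F)cc2)c1C1CC1`: 3.4 nM

Compound 3 stands lowest of the three numbers, beyond the scatter from both compound 1 and compound 2. Compound 4 `O=C(O)C[C@H](O)C[C@H](O)CCn1c(-c2ccc(F)cc2)nc(C(=O)NCc2ccccc2)c1C1CC1` differs from it by hydrogen in place of fluoro on an aromatic carbon. Within the data shown here, the only measured single-point step, a 1.3-fold higher number from compound 1 to compound 2 (0.12 log units; within the scatter), concerns a different part of the molecule and lies within the scatter, so no measured step bears on this change. No step beyond the scatter is therefore expected in this assay for compound 4, and the estimated step is a 1.3-fold higher number from compound 3 to compound 4 (0.12 log units; within the scatter). Compound 4 is expected to give about 4.5 nM, within a range from 1.8 nM to 11 nM.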

Compound 4, half-maximal inhibitory concentration in the 3-hydroxy-3-methylglutaryl-coenzyme A reductase assay: 1.4 nM
Compound 4: middle estimate off by 3.2-fold (0.51 log units), on the high side; measured number outside the range, below it.
By their numbers in the 3-hydroxy-3-methylglutaryl-coenzyme A reductase assay, from the lowest: compound 4; then compound 3; then compounds 1 and 2 (each within the scatter of the next).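

In the 3-hydroxy-3-methylglutaryl-coenzyme A reductase assay the fluoro of the 4-fluorobenzyl group proves dispensable, and its loss gives a 2.4-fold lower number from compound 3 to compound 4 (0.39 log units; beyond the scatter); this is a modest change beside the large steps at the cyclopropyl position, an 88-fold lower number from compound 2 to compound 4 (1.94 log units; beyond the scatter) and a 67-fold lower number from compound 1 to compound 4 (1.83 log units; beyond the scatter). In a physicochemical assay for lipophilicity, using the shake flask method, at pH 7.4 (on this read-out lower numbers stand for lower lipophilicity and higher numbers for higher lipophilicity), compound 3 gives 0.17 and compound 4 gives 0.03, and a number 0.14 log units lower from compound 3 to compound 4 (within the scatter) leaves the two compounds unseparated on this read-out. Nothing available explains the change in the 3-hydroxy-3-methylglutaryl-coenzyme A reductase assay. Still open, going by these compounds, is how chloro, methoxy or a carboxylic acid would behave at this place on the ring. Also open, on these data alone, is whether removing the fluoro gives a similar step with methyl or ethyl in place of cyclopropyl.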